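From compound 3 to its bromo analogue

The source may hold more compounds than are shown below. What is called first, only, known or untested is meant among the compounds shown, and "the series" means these compounds.

In a functional assay on MCF7 cells (Homo sapiens) for cytotoxicity, read by MTT assay, with a stated time of 24 h (a lower number here means a stronger inhibitor, a higher number a weaker inhibitor), compound 3 `O=c1nc2ccccn2cc1Cc1ccccc1` gives 75400 nM as its reading. Compound 1 `O=c1nc2ccc(Br)cn2cc1Cc1ccc(Br)cc1` gives 97200 nM and lies within the scatter of it. Compound 2 `O=c1nc2ccccn2cc1Cc1ccc(F)cc1` gives 200000 nM and stands clearly apart. Compound 4 `O=c1nc2ccccn2cc1Cc1ccc(Br)cc1` carries bromo in place of hydrogen on an aromatic carbon, para to a large group: bromo in place of hydrogen on an aromatic carbon in all. The closest measured change is a 2.7-fold lower number from compound 2 to compound 3 (0.42 log units; beyond the scatter) with hydrogen in place of fluoro on an aromatic carbon. Read backwards, that step points to a higher number. Yet compound 1, which also carries bromo, gives 97200 nM and so tempers it. The estimated step in this assay is a 1.5-fold higher number from compound 3 to compound 4 (0.16 log units; within the scatter) and is expected to be small, toward a higher number. Compound 4 is expected at 110000 nM with an estimated range from 55000 nM to 210000 nM overall.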

Compound 4, half-maximal inhibitory concentration: 157000 nM
Estimate against measurement, compound 4: 1.4-fold (0.15 log units) below; the range from low to high includes it.
By their numbers in this assay, from the lowest: compounds 3, 1, 4 and 2 (each within the scatter of the next, the first and the last beyond it).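

In this assay, bromo on the aromatic carbon para to a large group now gives a step of its own when it replaces hydrogen alone (a 2.1-fold higher number from compound 3 to compound 4 (0.32 log units; beyond the scatter)), in the same direction as fluoro there. Bromo and fluoro at this place are not told apart (a 1.3-fold lower number from compound 2 to compound 4 (0.11 log units; within the scatter)), and the step to the compound with a second bromo also stays within the scatter (a 1.6-fold higher number from compound 1 to compound 4 (0.21 log units; within the scatter)). Nothing at hand explains these steps. From the compounds shown here alone, it remains open whether an amine, a methoxy group or a carboxylic acid at this place would follow the two halogens or move the number the other way.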